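Removing the ring fluorine from a coumarin propargylamine

The source may hold more compounds than are shown below. What is called first, only, known or untested is meant among the compounds shown, and "the series" means these compounds.

Measured compounds:
- compound 1 `C#CCN(CCCOc1ccc2ccc(=O)oc2c1)Cc1ccc(OC)cc1` — 6080 nM
- compound 2 `C#CCN(CCCOc1ccc2ccc(=O)oc2c1)Cc1ccc(C)cc1` — 7380 nM
- compound 3 `C#CCN(CCCCOc1ccc2ccc(=O)oc2c1)Cc1cccc(F)c1` — 1550 nM

All three share the same core and were tested in an assay on isolated protein for inhibition of Amine oxidase [flavin-containing] B (Homo sapiens), read by fluorescence and Amplex Red, with stated times of 15 min and 20 min; a lower number here means a stronger inhibitor, a higher number a weaker inhibitor. Compound 1 and compound 2 differ only by methyl in place of methoxy on an aromatic carbon, and the step of a 1.2-fold higher number from compound 1 to compound 2 (0.08 log units; within the scatter) is within the scatter, so the two numbers cannot be told apart. Compound 3 gives the lowest number of the three; its gap to compound 1 and to compound 2 lies beyond the scatter, so it is the strongest inhibitor shown here.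

Compound 4 `C#CCN(CCCCOc1ccc2ccc(=O)oc2c1)Cc1ccccc1` has not been measured. It differs from compound 3 by hydrogen in place of fluoro on an aromatic carbon, meta to a large group. Within the data shown here, no measured pair shows this same change; the only single-place step available, from compound 1 to compound 2, concerns a different group and gives no direct guide. The step of a 1.5-fold higher number from compound 3 to compound 4 (0.17 log units; within the scatter) is expected to be small, with a slightly higher number somewhat more likely than a lower one. Compound 4 is therefore estimated at 2300 nM, within 1000 nM to 5500 nM.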

Compound 4, half-maximal inhibitory concentration: 978 nM
Compound 4: the middle estimate sits 2.4-fold (0.37 log units) above what was measured; measured number outside the range, below it.
By their numbers in this assay, from the lowest: compounds 4 and 3 (each within the scatter of the next); then compounds 1 and 2 (each within the scatter of the next).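

In this assay, replacing the fluoro of the 3-fluorobenzyl group with hydrogen, which leaves a plain benzyl group, gives a 1.6-fold lower number from compound 3 to compound 4 (0.20 log units; within the scatter), so the two compounds cannot be told apart. Among these compounds, this is the first direct reading of this place on the aromatic ring, meta to a large group, and it shows that the fluoro is not required for the inhibition seen with compound 3, as the unsubstituted phenyl ring gives a number within the same scatter. No measurement at hand explains why losing this single fluorine leaves the number where it is.

Still open, going by these compounds, is whether a chloro, a trifluoromethyl or a nitrile at this same place would move the number beyond the scatter, or stay as close as fluoro and hydrogen do here. On these data alone, it is also open whether fluoro and hydrogen would stay this close on the chain carried by compound 1 and compound 2, which differ from compound 4 in more than one place and so offer no clean comparison.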